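A few compounds are considered here, and "the series" means these few. Any claim that something is new, unique, unknown or untested is made for them only; others in the source may bear on it.

In a functional assay on Jurkat cells (Homo sapiens) for antiproliferative activity, read by MTT assay (a higher number here means a weaker inhibitor, a lower number a stronger inhibitor), compound 3 (`COc1cc2c(cc1OC)C(=O)/C(=C/c1ccc(O)cc1)CC2`) gives 19000 nM. Compound 2 (`COc1cc2c(cc1OC)C(=O)/C(=C/c1cccc(C)c1)CC2`) gives 17000 nM, and the two values lie within the scatter of each other. Compound 1 (`COc1ccccc1/C=C1\CCc2cc(OC)c(OC)cc2C1=O`) gives only a limit of the assay, > 50000 nM.

Compound 4 (`COc1cc2c(cc1OC)C(=O)/C(=C/c1ccc(O)c(C(=O)O)c1)CC2`) keeps the shared core and the hydroxy group of compound 3. It has carboxy in place of hydrogen on an aromatic carbon, ortho to a hydroxy group: carboxy in place of hydrogen on an aromatic carbon.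

Among the compounds with values here, no measured step adds a carboxy, so the nearest guides are the changes made to the phenyl group. One of them gave a 1.1-fold higher number from compound 2 to compound 3 (0.05 log units; within the scatter), while the two others gave an at least 2.9-fold lower number from compound 1 to compound 2 (0.46 log units; beyond the scatter) and an at least 2.6-fold lower number from compound 1 to compound 3 (0.42 log units; beyond the scatter). Changes on this group have therefore moved the number by a modest amount or not beyond the scatter, and compound 1 at > 50000 nM shows that weaker results occur here.

A modest move to a higher number is expected, a 2.1-fold higher number from compound 3 to compound 4 (0.32 log units; beyond the scatter). For compound 4 the estimated value is 40000 nM, with an expected range from 12000 nM to 100000 nM.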

Compound 4, half-maximal inhibitory concentration: > 50000 nM
Compound 4 ended at the assay's limit (the forecaster's own chance of this, stated with the estimate: 40%); at least 1.2-fold (0.09 log units) between middle value and limit.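

Putting carboxy in place of hydrogen on this aromatic carbon, ortho to a hydroxy group, gives an at least 2.6-fold higher number from compound 3 to compound 4 (0.42 log units; beyond the scatter) in this assay. The earlier steps shown here only exchanged one substituted phenyl group for another, whereas this step keeps the hydroxy group of compound 3 and adds a group to the same ring, and the added carboxy moves the number in the weaker direction. Compound 4 sits at a limit of the assay, so the step has a lower bound but no exact size: the limit of > 50000 nM in this assay, at which 2 of the 4 values shown sit.

On these data alone, whether a methyl ester, an amide or an amine on the same aromatic carbon would give the same result as carboxy remains open. Also open, as far as these compounds go, is what carboxy would do on the 3-methylphenyl group of compound 2.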